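Thiophen-3-yl to thiophen-2-yl on a shared core

The source may hold more compounds than are shown below. What is called first, only, known or untested is meant among the compounds shown, and "the series" means these compounds.

Measured in a functional assay on SW-620 cells (Homo sapiens) for antiproliferative activity, read by MTT assay, with a stated time of 24 h; a lower number here means a stronger inhibitor, a higher number a weaker inhibitor:
- compound 1 `COc1cccc(/C=C/C(=O)c2ccc(OC)c3c2OC(C)(C)C=C3)c1`: > 10000 nM
- compound 2 `COc1ccc(C(=O)/C=C/c2ccsc2)c2c1C=CC(C)(C)O2`: > 10000 nM

Neither entry is a number. Compound 2 stands at a limit of the assay, > 10000 nM. Compound 1 also gives only a limit, > 10000 nM. The whole record so far is the limit of > 10000 nM in this assay, at which 2 of the 2 values shown sit.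

Compound 3 `COc1ccc(C(=O)/C=C/c2cccs2)c2c1C=CC(C)(C)O2` has the same atoms as compound 2, joined differently: thiophen-2-yl in place of thiophen-3-yl on a double-bonded chain carbon bound to a double-bonded chain carbon. Thiophen-2-yl takes the place of thiophen-3-yl on a double-bonded chain carbon bound to a double-bonded chain carbon.

Within the data shown here, one measured step bears on this place, a step that the two limits leave unreadable from compound 1 to compound 2. It offers no size to carry over, so no step beyond the scatter is expected in this assay, and no direction can be named. This expectation rests on compound 2 with its limit of > 10000 nM. Compound 3 will most likely be reported as a limit too. As a number, the estimate for compound 3 is 15000 nM, with an expected range of 4000 nM to 50000 nM. The expected change is a step that the limit leaves unreadable from compound 2 to compound 3.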

Compound 3, half-maximal inhibitory concentration: > 10000 nM
Compound 3: a limit, no number (the forecaster's own chance of this, stated with the estimate: 80%); the middle value lies beyond the limit too.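

In this assay compound 3 gives > 10000 nM as a limit and not a number. No step can be read between compound 2 and compound 3 or between compound 1 and compound 3, and the record stays at a single limit: the limit of > 10000 nM in this assay, at which 3 of the 3 values shown sit.

The compounds shown leave open how thiophen-2-yl, thiophen-3-yl and 3-methoxyphenyl compare at this place on the shared core.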